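Ring exchange on the carbonyl carbon of a shared core

The source may report more compounds than this note shows. Statements on the series, on what has been measured and on what is new or still open speak of the compounds shown alone.

Compound 2 `Cc1cccc(C(=O)/C=C/c2ccc3c(c2)B(O)OC3)c1` gives 6700 nM in a functional assay on HCT-116 cells (Homo sapiens) for cytotoxicity, read by MTT assay, with a stated time of 48 h (a higher number here means a weaker inhibitor, a lower number a stronger inhibitor), the lowest of the two numbers measured, while compound 1 `Nc1ccc(C(=O)/C=C/c2ccc3c(c2)B(O)OC3)cc1` gives 26100 nM. The measured change was a 3.9-fold lower number from compound 1 to compound 2 (0.59 log units; beyond the scatter). Compound 3 `O=C(/C=C/c1ccc2c(c1)B(O)OC2)c1ccccc1O` differs from compound 2 by 2-hydroxyphenyl in place of 3-methylphenyl on a carbonyl carbon. Among the measured compounds shown here, no measured step covers this particular exchange; the single step available shows only that the ring on the carbonyl carbon can move the number beyond the scatter. The number for compound 3 is therefore expected to shift modestly, estimated at 12000 nM within 4000 nM to 40000 nM, a step of a 1.8-fold higher number from compound 2 to compound 3 (0.25 log units; within the scatter).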

Compound 3, half-maximal inhibitory concentration: 77900 nM
The estimate for compound 3 lay 6.5-fold (0.81 log units) below the measured number, outside the stated range (above it).
By their numbers in this assay, from the lowest: compound 2; then compound 1; then compound 3.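

On the carbonyl carbon, 2-hydroxyphenyl gives the highest number of the three in this assay and stands beyond the scatter from both other rings (a 12-fold higher number from compound 2 to compound 3 (1.07 log units; beyond the scatter); a 3.0-fold higher number from compound 1 to compound 3 (0.47 log units; beyond the scatter)). The position thus spreads the numbers further than the first step showed, and the exchange for 3-methylphenyl brings a large rise even though the heavy-atom count stays the same. Nothing available explains this rise. 

The compounds shown do not separate the hydroxyl from its place on the ring. On these data alone, what a methoxy group or a carboxylic acid on the ring would give here remains open.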